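Phenyl in place of cyclohexyl on the nitrogen

This account rests on a few compounds, and the source may have more. Where it says the series, first, only, none or still open, it means among the compounds named here.

In a functional assay (Nicotiana tabacum) (a lower number here means a stronger inhibitor, a higher number a weaker inhibitor), compound 1 (`CCCCNc1nc(SC)nc2ncccc12`), with butyl on the nitrogen, gives 270 nM. Compound 2 (`CCCCCCNc1nc(SC)nc2ncccc12`), with hexyl there, gives 3330 nM, and compound 3 (`CSc1nc(NC2CCCCC2)c2cccnc2n1`), with cyclohexyl, gives 5650 nM. Compound 3 therefore stands level with compound 2, the step being a 1.7-fold higher number from compound 2 to compound 3 (0.23 log units; within the scatter), and well on the weaker side of compound 1, the step being a 21-fold higher number from compound 1 to compound 3 (1.32 log units; beyond the scatter).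

Compound 4 (`CSc1nc(Nc2ccccc2)c2cccnc2n1`) keeps the core of compound 3 and carries phenyl in place of cyclohexyl on a nitrogen on an aromatic ring.

All measured steps concern this same nitrogen. Two are large: a 12-fold higher number from compound 1 to compound 2 (1.09 log units; beyond the scatter) and a 21-fold higher number from compound 1 to compound 3 (1.32 log units; beyond the scatter). Both start from the butyl group, so they say little about a change made on compound 3. Going by the values given here, the closest precedent is a 1.7-fold higher number from compound 2 to compound 3 (0.23 log units; within the scatter), which exchanges one large group for another without a shift beyond the scatter. Among the compounds with values here, no measured compound carries an aromatic group on this nitrogen, so the data give no direction for the change. No step beyond the scatter is expected, and the uncertainty is wide. The estimated step is a 1.3-fold lower number from compound 3 to compound 4 (0.10 log units; within the scatter). Compound 4 is expected at 4500 nM, with an estimated range from 900 nM to 22000 nM.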

Compound 4, half-maximal inhibitory concentration: 15900 nM
Beside the measured number, compound 4's estimate is 3.5-fold (0.55 log units) below it; measured number inside the range.
By their numbers in this assay, from the lowest: compound 1; then compounds 2 and 3 (each within the scatter of the next); then compound 4.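

In this assay, the only aromatic group shown on this nitrogen gives a step beyond the scatter, a 2.8-fold higher number from compound 3 to compound 4 (0.45 log units; beyond the scatter) for a swap that leaves the heavy-atom count unchanged, so a six-membered aromatic ring and a six-membered non-aromatic ring of carbon only are not interchangeable at this position. Hexyl and cyclohexyl could not be separated, but phenyl is separated from both: a 4.8-fold higher number from compound 2 to compound 4 (0.68 log units; beyond the scatter) in one case and a 59-fold higher number from compound 1 to compound 4 (1.77 log units; beyond the scatter) in the other, the widest step in the set, which leaves compound 4 as the weakest of the four, with its steps to all the others beyond the scatter. Nothing available explains the shift from cyclohexyl to phenyl.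

Still open, going by these compounds, is whether benzyl or methoxyphenyl on this nitrogen would stay as weak as phenyl or move back towards the values of the saturated groups. Propyl and pentyl would show whether butyl is a true optimum among the straight chains or just one point on a broader trend.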